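Cytotoxicity series: bromo in place of ethoxy

A few compounds are considered here, and "the series" means these few. Any claim that something is new, unique, unknown or untested is made for them only; others in the source may bear on it.

The series shares the core of compound 1 `CC(C)N(Cc1cccc(OCCCCCC(=O)O)c1)C(=O)c1ccccc1`. In an ADME assay on HEK293 cells (Homo sapiens) for cytotoxicity, read by CellTiter-Glo and resazurin assay, with a stated time of 72 h (a lower number here means that less compound is needed, a higher number that more compound is needed for the effect), compound 1 gives only a limit of the assay, > 26000 nM. Compound 2 `CC(C)N(Cc1cccc(OCCCCCC(=O)O)c1)C(=O)c1ccc(-c2ccncc2)cc1` carries pyridin-4-yl in place of hydrogen on an aromatic carbon. In this assay compound 2 likewise reaches only a limit, > 26000 nM. Compound 3 `CCOc1cccc(-c2ccc(C(=O)N(Cc3cccc(OCCCCCC(=O)O)c3)C(C)C)cc2)c1` carries 3-ethoxyphenyl in place of hydrogen on an aromatic carbon. In this assay compound 3 again stands at a limit, > 20800 nM. Compound 3 thus sits where the whole series sits, at the edge of what the assay reads. Two of the three values shown sit at the limit of > 26000 nM in this assay, at which 2 of the 3 values shown sit, and one at the limit of > 20800 nM in this assay, at which 1 of the 3 values shown sits.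

Compound 4 `CC(C)N(Cc1cccc(OCCCCCC(=O)O)c1)C(=O)c1ccc(-c2cccc(Br)c2)cc1` differs from compound 3 by bromo in place of ethoxy on an aromatic carbon. The measured steps that bear on this are a step that the two limits leave unreadable from compound 1 to compound 3, a step that the two limits leave unreadable from compound 2 to compound 3 and a step that the two limits leave unreadable from compound 1 to compound 2. None of them has a readable size: both ends of each are limits. Going by the values given here, no step in this assay is therefore expected beyond the scatter, in either direction. The step expected is a step that the limit leaves unreadable from compound 3 to compound 4. Compound 4 is expected in this assay at 30000 nM, within 15000 nM to 80000 nM, and most likely reported only as a limit.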

Compound 4, half-maximal effective concentration: > 26000 nM
Compound 4: only a limit was reported; the forecaster's own chance of this, stated with the estimate: 85%; the middle value lies beyond the limit too.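

In this assay compound 4 gives only a limit, > 26000 nM. Compound 1, compound 2 and compound 3 also stand at limits, so the steps from each of them to compound 4 cannot be read. The compounds shown leave open the size of every step in the series and the concentration at which any of them reaches half-maximal effect in this assay.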